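Carbamoylphenyl for Pyrazolyl: Cytotoxicity Outlook for Compound 4

A few compounds are considered here, and "the series" means these few. Any claim that something is new, unique, unknown or untested is made for them only; others in the source may bear on it.

Compound 1, `CCCn1cc2c(Nc3ccc(OC(F)(F)F)cc3)ncnc2n1`, in an ADME assay on BaF3 cells (Mus musculus) for cytotoxicity (on this read-out lower numbers stand for an effect already at smaller amounts and higher numbers for an effect only at larger amounts of compound), gives > 10000 nM, a limit of the assay.
Compound 2, `FC(F)(F)Oc1ccc(Nc2cc(-c3cn[nH]c3)ncn2)cc1`, in this assay gives > 10000 nM, likewise a limit.
Compound 3, `OCCn1cc2c(Nc3ccc(OC(F)(F)F)cc3)ncnc2n1`, in this assay gives > 10000 nM, again a limit.

Compound 2 therefore stands where every measured compound stands, at the limit of > 10000 nM in this assay, at which 3 of the 3 values shown sit. For the measured compounds named here, the one step between compounds differing in a single place, a step that the two limits leave unreadable from compound 1 to compound 3, cannot be read, as both of its ends are limits. Compound 4, `NC(=O)c1ccc(-c2cc(Nc3ccc(OC(F)(F)F)cc3)ncn2)cc1`, differs from compound 2 by 4-carbamoylphenyl in place of 1H-pyrazol-4-yl on an aromatic carbon. Going by the values given here, no measured step bears on this change, so the step from compound 2 to compound 4 in this assay is expected to be a number no higher from compound 2 to compound 4 (the limit leaves the size open), within the scatter. Compound 4 is estimated at 10000 nM, with a range from 3000 nM to 30000 nM, most likely reported as a limit once more.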

Compound 4, half-maximal effective concentration: > 10000 nM
Compound 4: no number, only a limit; the forecaster's own chance of this, stated with the estimate: 80%; the middle value sits exactly at the limit.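

The step between compound 2 and compound 4 cannot be read, since both of its ends are limits: the limit of > 10000 nM in this assay, at which 4 of the 4 values shown sit. The compounds shown leave open at what concentration any of them would reach a half-maximal effect in this assay.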